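The source may report more compounds than this note shows. Statements on the series, on what has been measured and on what is new or still open speak of the compounds shown alone.

Series notes. Two members of the series have been run in a functional assay on SW1573 cells (Homo sapiens) for antiproliferative activity, read by sulforhodamine B assay, with a stated time of 48 h; a higher number here means a weaker inhibitor of growth, a lower number a stronger inhibitor of growth. Compound 1 `CCCCCCC[C@H]1C[C@H](Cl)CCN1S(=O)(=O)c1ccc(C)cc1` gives > 100000 nM in this assay, which is a limit of the assay rather than a number. For the measured compounds named here, compound 2 `Cc1ccc(S(=O)(=O)N2CC[C@@H](Br)C[C@@H]2CC(C)C)cc1` gives 22000 nM in this assay, the only number recorded so far. The other recorded value, that of compound 1, is a limit of the assay, and compound 2 thus cannot be ranked against any measured partner. Going by the values given here, compound 1 and compound 2 differ in more than one place, so no single step between them is computed.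

Compound 3 `CCCCCCC[C@H]1C[C@H](Br)CCN1S(=O)(=O)c1ccc(C)cc1` is the next member to be measured. It differs from compound 2 by hexyl in place of isopropyl on a saturated chain carbon bound to a saturated ring carbon. Among the compounds with values here, no step between measured compounds exists to calibrate this change. Within the data shown here, the only other measured compound, compound 1, sits at the limit of > 100000 nM in this assay, at which 1 of the 2 values shown sits, in this assay, and with that as the sole anchor the step from compound 2 to compound 3 is expected to run toward weaker growth inhibition, beyond the scatter, at roughly a 2.7-fold higher number from compound 2 to compound 3 (0.44 log units; beyond the scatter). Compound 3 is accordingly estimated at 60000 nM in this assay, within a range from 20000 nM to 150000 nM, with a fair chance that only a limit is returned.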

Compound 3, concentration for 50% growth inhibition: > 100000 nM
Compound 3: no number, only a limit; the forecaster's own chance of this, stated with the estimate: 45%; middle value at least 1.6-fold (0.22 log units) from the limit.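

For the compounds shown here, on the saturated chain carbon bound to a saturated ring carbon, hexyl in place of isopropyl gives the first readable step in this assay, an at least 4.5-fold higher number from compound 2 to compound 3 (0.65 log units; beyond the scatter), so the longer chain goes with weaker growth inhibition in this one pair. Compound 3 gives > 100000 nM, which is a limit of the assay and not a number. The step from compound 1 to compound 3, bromo in place of chloro on a saturated ring carbon, cannot be read from its two limits, and with hexyl on the chain neither halogen gives a number, so compound 2 still holds the only number in the series: the limit of > 100000 nM in this assay, at which 2 of the 3 values shown sit.

Where growth inhibition is lost between isopropyl and hexyl remains open, as does whether a shorter chain such as ethyl, or a chain ending in an amine or a carboxylic acid, would give a lower number than compound 2. As far as these compounds go, how bromo compares with chloro, or with a hydroxyl, on the saturated ring carbon also stays open until a pair gives numbers on both sides.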